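The source may report more compounds than this note shows. Statements on the series, on what has been measured and on what is new or still open speak of the compounds shown alone.

Compound 1 `N#Cc1c(-c2ccccc2)c(C#N)c(=O)n(/N=C/c2cn(-c3ccccc3)nc2-c2ccccc2)c1N` gives 180 ug/mL in an ADME assay on NIH3T3 cells (Mus musculus) for cytotoxicity, read by MTT assay; on this read-out lower numbers stand for stronger inhibition and higher numbers for weaker inhibition. Compound 2 `Cc1ccc(-c2c(C#N)c(N)n(/N=C/c3cn(-c4ccccc4)nc3-c3ccccc3)c(=O)c2C#N)cc1` gives 98 ug/mL.

Of the two numbers, compound 2 has the lower one, with compound 1 nearest. The step of a 1.8-fold lower number from compound 1 to compound 2 (0.26 log units; within the scatter) is within the scatter, so the two are not separated. Compound 3 `N#Cc1c(-c2ccccc2[N+](=O)[O-])c(C#N)c(=O)n(/N=C/c2cn(-c3ccccc3)nc2-c2ccccc2)c1N` differs from compound 2 by 2-nitrophenyl in place of 4-methylphenyl on an aromatic carbon. No measured step covers this change; the single step shown, a methyl for a hydrogen on the same ring, stayed within the scatter. Compound 3 is therefore expected near 120 ug/mL, between 50 ug/mL and 260 ug/mL, an estimated step of a 1.2-fold higher number from compound 2 to compound 3 (0.09 log units; within the scatter) not beyond the scatter.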

Compound 3, half-maximal inhibitory concentration: > 200 ug/mL
Compound 3 ended at the assay's limit; the forecaster's own chance of this, stated with the estimate: 10%; middle value at least 1.6-fold (0.22 log units) from the limit.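

In this assay, compound 3 reads as a limit of the assay and not as a number: the limit of > 200 ug/mL in this assay, at which 1 of the 3 values shown sits.

Placing 2-nitrophenyl opposite the ring nitrogen in place of 4-methylphenyl gives an at least 2.0-fold higher number from compound 2 to compound 3 (0.30 log units; that floor lies within the scatter), while nitro in place of hydrogen on the phenyl gives an at least 1.1-fold higher number from compound 1 to compound 3 (0.04 log units; that floor lies within the scatter). This position therefore carries a nitro-bearing ring without any lower number appearing, though neither floor separates the compounds.

As far as these compounds go, how far compound 3 truly lies from the other two remains open. So does whether an amine or a carboxylic acid on that phenyl ring would give a lower or a higher number.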